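Amide bearing carboxy ester in place of propargyl ester

The source may hold more compounds than are shown below. What is called first, only, known or untested is meant among the compounds shown, and "the series" means these compounds.

Compound 1 `CCn1c(C(=O)NCCCN(C)C)ccc1C(CC)(CC)c1ccc(OCCC(O)(CC)CC)c(C)c1`, compound 2 `C#CC(C)OC(=O)c1ccc(C(CC)(CC)c2ccc(OCCC(O)(CC)CC)c(C)c2)n1CC` and compound 3 `CCC(C)C(NC(=O)c1ccc(C(CC)(CC)c2ccc(OCCC(O)(CC)CC)c(C)c2)n1CC)C(=O)O` share one core and differ only at the carbonyl carbon. In an ADME assay on L02 cells (Homo sapiens) for antiproliferative activity, read by MTT assay, with a stated time of 48 h (on this read-out higher numbers stand for weaker inhibition and lower numbers for stronger inhibition), compound 1 gives 2420 nM and compound 3 gives 9990 nM. For compound 2 this assay reports only a limit, > 50000 nM, the highest of the three. Compound 4 `CCn1c(C(=O)NC(CC(=O)O)C(=O)OC)ccc1C(CC)(CC)c1ccc(OCCC(O)(CC)CC)c(C)c1` is the unmeasured partner: a group of 10 heavy atoms (5 carbon, 1 nitrogen, 4 oxygen; no ring) in place of a group of 5 heavy atoms (4 carbon, 1 oxygen; no ring), on a carbonyl carbon. The closest measured step is an at least 5.0-fold lower number from compound 2 to compound 3 (0.69 log units; beyond the scatter), where a carboxy-bearing amide likewise replaced the ester, and an at least 20-fold higher number from compound 1 to compound 2 (1.31 log units; beyond the scatter) shows the ester far above the amide side. Compound 4 is therefore expected to fall back below the limit, with an at least 3.3-fold lower number from compound 2 to compound 4 (0.52 log units; beyond the scatter). The estimate for compound 4 in this assay is 15000 nM, ranging from 5000 nM to 50000 nM.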

Compound 4, half-maximal inhibitory concentration: 7590 nM
Estimate against measurement, compound 4: 2.0-fold (0.30 log units) above; measured number inside the range.
By their numbers in this assay, from the lowest: compound 1; then compounds 4 and 3 (each within the scatter of the next). At a limit, above all of these: compound 2.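

In this assay a second carboxy-bearing amide on the carbonyl carbon again lies well under the ester (an at least 6.5-fold lower number from compound 2 to compound 4 (0.81 log units; beyond the scatter)), and it cannot be told apart from the first (a 1.3-fold lower number from compound 3 to compound 4 (0.12 log units; within the scatter)), although the groups on the amide-type nitrogen differ. Compound 4 still does not reach the 3-(dimethylamino)propyl amide (a 3.1-fold higher number from compound 1 to compound 4 (0.50 log units; beyond the scatter)). Compound 2 remains a limit, so the first of these steps has no upper bound: the limit of > 50000 nM in this assay, at which 1 of the 4 values shown sits.

On these data alone, it remains open whether the carboxylic acid or the methyl ester of compound 4 sets its number. As far as these compounds go, how a longer amine chain or a primary amine on the amide-type nitrogen would compare with compound 1 is also open.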